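Changing the aromatic ring on a carbonyl group

A few compounds are considered here, and "the series" means these few. Any claim that something is new, unique, unknown or untested is made for them only; others in the source may bear on it.

In an ADME assay on cells (Hepatocyte, Mus musculus) for metabolic stability, with a stated time of 30 min (on this read-out higher numbers stand for a more stable compound and lower numbers for a less stable compound), two related compounds lie far apart. Compound 1 (`CS(=O)(=O)NC1CCC(CN2CCN(c3cc(=O)c4cc(C(F)(F)F)cc([N+](=O)[O-])c4s3)CC2)CC1`) reads 111% on this scale, while compound 2 (`Cc1ccc(C(=O)OC2CCC(CN3CCN(c4cc(=O)c5cc(C(F)(F)F)cc([N+](=O)[O-])c5s4)CC3)CC2)cc1`) reads 18% and so holds the lower of the two numbers. Within the data shown here, the only measured step between them is large: ((4-methylphenyl)carbonyl)oxy in place of methanesulfonamido on a saturated ring carbon gives a number 93 percentage points lower from compound 1 to compound 2 (beyond the scatter) in this comparison.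

Compound 3 (`O=C(OC1CCC(CN2CCN(c3cc(=O)c4cc(C(F)(F)F)cc([N+](=O)[O-])c4s3)CC2)CC1)c1ccco1`) differs from compound 2 in one place, furan-2-yl in place of 4-methylphenyl on a carbonyl carbon. That measured step offers only limited guidance, as it swapped the whole group on the saturated ring carbon. Here the carbonyl and its oxygen stay, and only the aromatic ring changes. Among the measured compounds shown here, no measured pair shows a swap of this smaller kind, so the best anchor is compound 2 at 18% in the same test.

The expected change is small, a number 3 percentage points lower from compound 2 to compound 3 (within the scatter) in the estimate, and so not beyond the scatter. For compound 3 the expected value is 15% (estimated range 3% to 38%).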

Compound 3, percent of the compound remaining: 0.6%
Compound 3: the middle estimate sits 14.4 percentage points above what was measured; measured number outside the range, below it.
By their numbers in this assay, from the lowest: compound 3; then compound 2; then compound 1.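

With the carbonyl and its oxygen kept and only the aromatic ring changed, this assay gives a number 17.4 percentage points lower from compound 2 to compound 3 (beyond the scatter); this shows that the ring on the carbonyl carbon can move the read-out beyond the scatter by itself, whereas the earlier step exchanged the whole group on the saturated ring carbon. Replacing methanesulfonamido with ((furan-2-yl)carbonyl)oxy gives a number 110.4 percentage points lower from compound 1 to compound 3 (beyond the scatter), so among these compounds both groups with a carbonyl and its oxygen lie far below compound 1, while the ring on the carbonyl carbon separates the two further. Nothing available explains why the number falls with furan-2-yl, so the result remains an observation.

Furan-2-yl differs from 4-methylphenyl in ring size, in its ring oxygen and in lacking a methyl group, and the compounds shown cannot separate these differences; plain phenyl or thiophen-2-yl on the same carbonyl carbon would help to tell them apart. As far as these compounds go, it also remains open how these rings would behave if an amide nitrogen replaced the oxygen next to the carbonyl group.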